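The source may hold more compounds than are shown below. What is called first, only, known or untested is meant among the compounds shown, and "the series" means these compounds.

Of the compounds shown here, three built on one shared core have so far been tested in a functional assay (Mus musculus, strain Balb/c) for inhibition, read by ELISA, with a stated time of 72 h; on this read-out lower numbers stand for stronger inhibition and higher numbers for weaker inhibition. Compound 1 `COc1ccc(C(/C=C/c2ccc(Cl)cc2)=N/O)cc1` gives 11500 nM. Compound 2 `COc1ccc(C(/C=C/c2ccc(Br)cc2)=N/O)cc1` gives 13900 nM, and the step of a 1.2-fold higher number from compound 1 to compound 2 (0.08 log units; within the scatter) stays within the scatter. Compound 3 `Cc1ccc(C(/C=C/c2ccc(Cl)cc2)=N/O)cc1` gives 11600 nM; on the numbers shown it stands second highest of the three, with compound 1 nearest at a number indistinguishable from its own and compound 2 furthest, still within the scatter. The step of a 1.0-fold higher number from compound 1 to compound 3 (0.00 log units; within the scatter) likewise lies within the scatter.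

Compound 4 `Cc1ccc(C(/C=C/c2ccc(Br)cc2)=N/O)cc1` has not yet been measured. The change from compound 3 to compound 4 is bromo in place of chloro on an aromatic carbon. For the measured compounds named here, one measured step bears directly on it, namely a 1.2-fold higher number from compound 1 to compound 2 (0.08 log units; within the scatter), the same exchange carried out on another pair of the set, which stayed within the scatter. On that basis no step beyond the scatter is expected in this assay, and the number for compound 4 is estimated to lie close to that of compound 3. Compound 4 is therefore expected to give 13500 nM, with a range from 7000 nM to 26000 nM. The expected step is a 1.2-fold higher number from compound 3 to compound 4 (0.07 log units; within the scatter).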

Compound 4, half-maximal inhibitory concentration: 11600 nM
The estimate for compound 4 lay 1.2-fold (0.07 log units) above the measured number, and the stated range covers the measured number.
By their numbers in this assay, from the lowest: compounds 1, 3, 4 and 2 (each within the scatter of the next).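

In this assay, bromo in place of chloro on an aromatic carbon has now been read on a second core, with the methyl group in place of the methoxy group, and the step (no change at the digits printed from compound 3 to compound 4 (within the scatter)) agrees with the one seen earlier: the same change on two cores in this assay, a 1.2-fold higher number (0.08 log units; within the scatter) from compound 1 to compound 2 and no change at the digits printed (within the scatter) from compound 3 to compound 4, 1.2-fold (0.08 log units) apart, within the scatter of two such steps. The methyl for methoxy exchange can now also be read with bromo present instead of chloro (a 1.2-fold lower number from compound 2 to compound 4 (0.08 log units; within the scatter)), and it too agrees with its earlier counterpart: the same change on two cores in this assay, a 1.0-fold higher number (0.00 log units; within the scatter) from compound 1 to compound 3 and a 1.2-fold lower number (0.08 log units; within the scatter) from compound 2 to compound 4, 1.2-fold (0.08 log units) apart, within the scatter of two such steps. Among these four compounds, then, neither exchange reads differently according to what stands at the other place, and no compound goes against this, although the statement holds only for these two small changes.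

What an amine or a carboxylic acid would do in place of the halogen, or a longer chain such as butoxy in place of the methoxy group, stays open, since the compounds shown span only chloro and bromo at one place and methoxy and methyl at the other. The shared core is the same in all four compounds, so what its other parts contribute to the inhibition cannot be told from these numbers.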